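Chain extension at the sulfone terminus: compound 3 to compound 4

The source may report more compounds than this note shows. Statements on the series, on what has been measured and on what is new or still open speak of the compounds shown alone.

Three catechol vinyl sulfones share one core and differ only in the saturated chain on the sulfonyl sulfur. Compound 1 `CCCCCCCS(=O)(=O)/C=C/c1ccc(O)c(O)c1` carries a heptyl chain; in a functional assay, read by fluorescence and spectrophotometry, with a stated time of 1 h (a higher number here means that more compound is needed for the effect, a lower number that less compound is needed), compound 1 gives 7100 nM. Compound 2 `C=CCCCCCS(=O)(=O)/C=C/c1ccc(O)c(O)c1` ends in a terminal alkene, and in this assay compound 2 gives 7100 nM. Compound 3 `C=CCCCCCCS(=O)(=O)/C=C/c1ccc(O)c(O)c1` places the terminal alkene one carbon further out; in this assay compound 3 gives 6400 nM, the lowest of the three numbers, though its gap to each neighbour is within the scatter: a 1.1-fold lower number from compound 1 to compound 3 (0.05 log units; within the scatter) and a 1.1-fold lower number from compound 2 to compound 3 (0.05 log units; within the scatter), while no change at the digits printed from compound 1 to compound 2 (within the scatter).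

Compound 4 `C=CCCCCCCCS(=O)(=O)/C=C/c1ccc(O)c(O)c1` continues the series by one carbon: allyl in place of vinyl on a saturated chain carbon, six bonds along the chain from a sulfonyl sulfur. Among the measured compounds shown here, the steps that bear on it are the chain changes already seen, all within the scatter, including the earlier allyl-for-vinyl exchange five bonds along and the vinyl-for-methyl exchange six bonds along. On that basis no step beyond the scatter is expected in this assay, and the estimated change is no change at the digits printed from compound 3 to compound 4 (within the scatter). Compound 4 is therefore expected to give about 6400 nM in this assay, with a plausible range from 3200 nM to 12800 nM.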

Compound 4, half-maximal effective concentration: 6900 nM
Estimate against measurement, compound 4: 1.1-fold (0.03 log units) below; the measured number falls inside the stated range.
By their numbers in this assay, from the lowest: compounds 3, 4, 1 and 2 (each within the scatter of the next).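

In this assay, the exchange of allyl for vinyl, six bonds along the chain from a sulfonyl sulfur, gives a 1.1-fold higher number from compound 3 to compound 4 (0.03 log units; within the scatter) and so stays within the scatter at this place as it did five bonds along. The larger changes that compound 4 now allows also stay within the scatter: but-3-en-1-yl in place of vinyl, five bonds along, gives a 1.0-fold lower number from compound 2 to compound 4 (0.01 log units; within the scatter) and vinyl in place of hydrogen, seven bonds along, gives a 1.0-fold lower number from compound 1 to compound 4 (0.01 log units; within the scatter) so that every step among the four listed chains lies within the scatter, and no compound goes against this. Nothing available explains why these chain changes leave the number within the scatter.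

The compounds shown leave open whether a longer chain than that of compound 4 would also stay within the scatter in this assay or whether a step beyond it would appear. They also leave open what a hydroxyl, an amine or a carboxylic acid at the chain end would do in place of the terminal alkene.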